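Exchange of hydroxy for 4-methylpiperazin-1-yl on the chain

The compounds below may be only part of what the source reports. "The series", "measured", "known", "first", "only" and "open" are said of these compounds alone.

In an ADME assay on MRC5 cells (Homo sapiens) for cytotoxicity, read by fluorescence and resazurin assay, with a stated time of 3 days (on this read-out lower numbers stand for an effect already at smaller amounts and higher numbers for an effect only at larger amounts of compound), compound 1 `CCOC(=O)Nc1ccc(S(=O)(=O)n2c(C3(O)C=CC(=O)C=C3)cc3ccccc32)cc1` gives 86 nM. Compound 2 `O=C1C=CC(O)(c2cc3ccccc3n2S(=O)(=O)c2ccc(CCCO)cc2)C=C1` gives 51 nM, which lies within the scatter of compound 1, so the two numbers shown so far cannot be told apart.

Compound 3 `CN1CCN(CCCc2ccc(S(=O)(=O)n3c(C4(O)C=CC(=O)C=C4)cc4ccccc43)cc2)CC1` is still unmeasured. Its difference from compound 2 is 4-methylpiperazin-1-yl in place of hydroxy on a saturated chain carbon, three bonds along the chain from an aromatic carbon, turning 3-hydroxypropyl into 3-(4-methylpiperazin-1-yl)propyl.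

For the measured compounds named here, only one measured step bears on this, and only indirectly: a 1.7-fold lower number from compound 1 to compound 2 (0.23 log units; within the scatter). That step exchanged a different pair of groups, on an aromatic carbon, and stayed within the scatter. Going by the values given here, no measured compound carries 4-methylpiperazin-1-yl, so the data offer no direction for this change.

No shift beyond the scatter is therefore expected in this assay. The estimated step is a 1.3-fold higher number from compound 2 to compound 3 (0.11 log units; within the scatter). For compound 3 the expected value is 65 nM, with an estimated range from 22 nM to 190 nM.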

Compound 3, half-maximal effective concentration: 50 nM
Compound 3: middle estimate off by 1.3-fold (0.11 log units), on the high side; the range from low to high includes it.
By their numbers in this assay, from the lowest: compounds 3, 2 and 1 (each within the scatter of the next).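

In this assay, for the compounds shown here, the first direct reading at this chain position is a 1.0-fold lower number from compound 2 to compound 3 (0.01 log units; within the scatter): 4-methylpiperazin-1-yl, with its six-membered non-aromatic ring, and hydroxy cannot be told apart here. The comparison on the aromatic carbon, a 1.7-fold lower number from compound 1 to compound 3 (0.24 log units; within the scatter), also stays within the scatter, so 3-(4-methylpiperazin-1-yl)propyl, 3-hydroxypropyl and (ethoxycarbonyl)amino give no separable numbers on the shared core. No supporting measurement is available to account for this result.

Still open, as far as these compounds go, is whether a carboxylic acid in place of hydroxy on the same chain carbon would also stay within the scatter, since both groups seen there so far give numbers that cannot be separated. A longer chain carrying 4-methylpiperazin-1-yl is equally untested by the compounds shown.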